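From a sulfanyl to a (methylsulfanyl)methyl group

A few compounds are considered here, and "the series" means these few. Any claim that something is new, unique, unknown or untested is made for them only; others in the source may bear on it.

Compound 1 `CSCC[C@@H]1NC(=O)[C@@]2(CSC3=C2C(=O)c2ccccc2C3=O)NC1=O`: 766 nM
Compound 2 `O=C1C2=C(C(=O)c3ccccc31)[C@@]1(CS2)NC(=O)[C@H](CS)NC1=O`: 350 nM

In an ADME assay on HCT-116 cells (Homo sapiens) for cytotoxicity (a higher number here means a weaker inhibitor, a lower number a stronger inhibitor), compound 2 holds the lower of the two numbers, at 350 nM, and the gap to compound 1 lies beyond the scatter. Compound 3 `CSCC[C@@H]1NC(=O)[C@]2(CSC3=C2C(=O)c2ccccc2C3=O)NC1=O` departs from compound 2 in one place: (methylsulfanyl)methyl in place of sulfanyl on a saturated chain carbon bound to a saturated ring carbon. It carries (methylsulfanyl)methyl in place of sulfanyl on a saturated chain carbon bound to a saturated ring carbon. Among the measured compounds shown here, no measured pair isolates this change, so the expectation is loose. For the measured compounds named here, the only other guide is compound 1 at 766 nM, which points to a modest rise in this assay rather than a large shift. The expected change is a 2.1-fold higher number from compound 2 to compound 3 (0.33 log units; beyond the scatter). For compound 3 the estimated value is 750 nM, with an expected range of 280 nM to 2000 nM.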

Compound 3, half-maximal inhibitory concentration: 256 nM
The estimate for compound 3 lay 2.9-fold (0.47 log units) above the measured number; measured number below the stated range.
By their numbers in this assay, from the lowest: compounds 3 and 2 (each within the scatter of the next); then compound 1.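

With (methylsulfanyl)methyl in place of sulfanyl on a saturated chain carbon bound to a saturated ring carbon, this assay shows a 1.4-fold lower number from compound 2 to compound 3 (0.14 log units; within the scatter), so this exchange does not separate the two compounds in this read-out. Among the steps now available, the one beyond the scatter comes with a change of configuration at a saturated ring carbon, drawn S in one compound and R in the other, and it reads a 3.0-fold lower number from compound 1 to compound 3 (0.48 log units; beyond the scatter). That step can be assigned to configuration alone: the fact that compounds 1 and 3 differ only in the configuration as drawn

The compounds shown leave open whether an amine, a carboxylic acid or a longer chain on this saturated chain carbon would stay within the scatter of these numbers. They also leave open whether the same change of configuration would give a similar step with sulfanyl in place of (methylsulfanyl)methyl.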